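Replacing Dimethylamino by Hydroxy: an Expected Affinity Shift

The source may hold more compounds than are shown below. What is called first, only, known or untested is meant among the compounds shown, and "the series" means these compounds.

Measured compounds:
compound 1, `CCCN(CCC)c1cc(C)nc2c(-c3ncc(N=O)cc3C)c(C)nn12`, 100 nM
compound 2, `CCCN(CCC)c1cc(C)nc2c(-c3ncc(O)cc3C)c(C)nn12`, 530 nM
compound 3, `CCCN(CCC)c1cc(C)nc2c(-c3ncc(C)cc3N(C)C)c(C)nn12`, 23 nM

In an assay on isolated protein for binding affinity to corticotropin-releasing factor receptor 1 (Homo sapiens) (a lower number here means a stronger inhibitor, a higher number a weaker inhibitor), compound 3 gives 23 nM, the lowest of the three numbers measured. Its nearest neighbour is compound 1, whose value in this assay is 100 nM; compound 2, at 530 nM, lies furthest away, and both gaps exceed the usual scatter.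

Compound 4, `CCCN(CCC)c1cc(C)nc2c(-c3ncc(C)cc3O)c(C)nn12`, has not yet been measured. It differs from compound 3 by hydroxy in place of dimethylamino on an aromatic carbon. Going by the values given here, only one measured step resembles this change: from compound 1 to compound 2, a hydroxy group also entered on the six-membered aromatic ring with one nitrogen, and the result was a 5.3-fold higher number from compound 1 to compound 2 (0.72 log units; beyond the scatter). Among the compounds with values here, that step swaps out a different group at a different spot, so it is only a loose guide, but it is the sole evidence on a hydroxy entering this ring, and it points towards a weaker binder. Compound 2 and compound 4 carry their hydroxy and methyl groups at different places, so their values cannot be compared directly.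

Compound 4 is therefore expected to show a 4.3-fold higher number from compound 3 to compound 4 (0.64 log units; beyond the scatter), giving an estimated value of 100 nM in this assay, with a likely range from 35 nM to 300 nM.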

Compound 4, inhibition constant: > 10000 nM
Compound 4 ended at the assay's limit; the forecaster's own chance of this, stated with the estimate: 5%; middle value at least 100-fold (2.00 log units) from the limit.
By their numbers in this assay, from the lowest: compound 3; then compound 1; then compound 2. At a limit, above all of these: compound 4.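

In this assay compound 4 gives > 10000 nM, which is a limit of the assay: the limit of > 10000 nM in this assay, at which 1 of the 4 values shown sits. On the aromatic carbon ortho to a large group and two atoms from the ring nitrogen, hydroxy in place of dimethylamino gives an at least 430-fold higher number from compound 3 to compound 4 (2.63 log units; beyond the scatter), a far larger change than the one seen when hydroxy entered at a different spot on the ring, a 5.3-fold higher number from compound 1 to compound 2 (0.72 log units; beyond the scatter). Placement on the ring proves decisive, for 3-hydroxy-5-methylpyridin-2-yl in place of 5-hydroxy-3-methylpyridin-2-yl gives an at least 18-fold higher number from compound 2 to compound 4 (1.27 log units; beyond the scatter), and the wider change in the same ring substituent gives an at least 100-fold higher number from compound 1 to compound 4 (2.00 log units; beyond the scatter), so a hydroxy on this ring does not by itself bring a loss of this size.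

The compounds shown leave open whether the loss comes from the hydroxy entering or from the dimethylamino leaving. They also do not tell how a methoxy, a primary amine or a plain methyl group would fare at this same place, and any of these would help to separate the two readings.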